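A Dichlorophenyl Carbonyl Replaces Acetyl: Expecting a Large Rise

A few compounds are considered here, and "the series" means these few. Any claim that something is new, unique, unknown or untested is made for them only; others in the source may bear on it.

Of the compounds shown here, three built on a shared core have been measured in a functional assay on MDA-MB-231 cells (Homo sapiens) for inhibition, read by sulforhodamine B assay, tested at 10 uM; a lower number here means less inhibition, a higher number more inhibition at the concentration tested (going by the name of the read-out). Compound 1 `CC(=O)N1N=C(c2ccc(N3CCN(C)CC3)cc2)CC1c1ccc(N(C)C)cc1` gives -1%. Compound 2 `CN1CCN(c2ccc(C3=NN(C(=O)c4ccc(C(F)(F)F)cc4)C(c4ccc(N(C)C)cc4)C3)cc2)CC1` gives 55.4%. Compound 3 `CC(=O)N1N=C(c2ccc(-n3cncn3)cc2)CC1c1ccc(N(C)C)cc1` gives 7.4%, the second highest of the three numbers; compound 1 is its nearest neighbour, within the scatter, while compound 2 lies far above it, beyond the scatter. Compound 4 `CN(C)c1ccc(C2CC(c3ccc(-n4cncn4)cc3)=NN2C(=O)c2cc(Cl)cc(Cl)c2)cc1` has not yet been measured and differs from compound 3 in one place: 3,5-dichlorophenyl in place of methyl on a carbonyl carbon. Going by the values given here, one measured step bears directly on this change, namely a number 56.4 percentage points higher from compound 1 to compound 2 (beyond the scatter), where a substituted phenyl likewise took the place of methyl on a carbonyl carbon. The other step, a number 8.4 percentage points higher from compound 1 to compound 3 (within the scatter), concerns an aromatic carbon elsewhere and stayed within the scatter. By analogy with the first step, a large rise in this assay is expected for compound 4, though the substituted phenyl here differs, so its size is uncertain; the expected step is a number 42.6 percentage points higher from compound 3 to compound 4 (beyond the scatter). Compound 4 is accordingly estimated at 50%, with a range from 20% to 75%.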

Compound 4, a percentage reported as inhibition, at one concentration (the size of the read-out at that concentration, not a potency): 9.4%
Compound 4: the middle estimate sits 40.6 percentage points above what was measured; measured number outside the range, below it.
By their numbers in this assay, from the lowest: compounds 1, 3 and 4 (each within the scatter of the next, the first and the last beyond it); then compound 2.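

In this assay, putting 3,5-dichlorophenyl in place of methyl on a carbonyl carbon gives a number 2 percentage points higher from compound 3 to compound 4 (within the scatter), so an aromatic ring at this position does not by itself bring a large rise. The large step seen earlier, a number 56.4 percentage points higher from compound 1 to compound 2 (beyond the scatter), therefore cannot be read as general for this position: it holds for 4-(trifluoromethyl)phenyl with 4-methylpiperazin-1-yl at the other end of the molecule, while this step has a different ring with 1H-1,2,4-triazol-1-yl there. No measurement at hand accounts for the contrast between the two steps.

The compounds shown leave open whether the large rise follows the 4-(trifluoromethyl)phenyl group, the 4-methylpiperazin-1-yl group or the pairing of the two. They also leave open how a phenyl ring carrying an amine or a carboxylic acid, or a longer chain in place of the methyl, would read at this carbonyl carbon.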